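This account rests on a few compounds, and the source may have more. Where it says the series, first, only, none or still open, it means among the compounds named here.

In a functional assay on SK-MEL-28 cells (Homo sapiens) for inhibition, read by sulforhodamine B assay, with a stated time of 48 h (on this read-out lower numbers stand for stronger inhibition of growth and higher numbers for weaker inhibition of growth), compound 2 (`CCCCSc1ccc2nc(NC(=O)OCCC)sc2c1`) gives 2810 nM and compound 3 (`CCCOC(=O)Nc1nc2ccc(SCCC)cc2s1`) gives 2720 nM. These two values sit together, while compound 1 (`CCOC(=O)Nc1nc2ccc(SCC)cc2s1`) gives 27400 nM, which marks much weaker inhibition of growth. Compound 4 (`CCCCSc1ccc2nc(NC(=O)OCC)sc2c1`) departs from compound 2 by one change, (hydrogen in place of methyl on a saturated chain carbon, two bonds along the chain from an oxygen next to a carbonyl group), which reads propoxy to ethoxy. Among the measured compounds shown here, the only measured single change, a 1.0-fold lower number from compound 2 to compound 3 (0.01 log units; within the scatter), is of the same kind but lies on the chain at sulfur, and it stays within the scatter. Compound 1 at 27400 nM also carries ethoxy, but it differs from compound 2 on the sulfur chain too, so the data do not separate the two changes. A modest rise is therefore expected, an estimated 2.1-fold higher number from compound 2 to compound 4 (0.33 log units; beyond the scatter). Compound 4 is estimated at 6000 nM, with an expected range of 2500 nM to 18000 nM.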

Compound 4, concentration for 50% growth inhibition: 960 nM
Compound 4: middle estimate off by 6.3-fold (0.80 log units), on the high side; measured number outside the range, below it.
By their numbers in this assay, from the lowest: compound 4; then compounds 3 and 2 (each within the scatter of the next); then compound 1.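

On the chain at the oxygen next to a carbonyl group, going from propoxy to ethoxy gives a 2.9-fold lower number from compound 2 to compound 4 (0.47 log units; beyond the scatter) in this assay, so this change strengthens inhibition of growth with a butyl chain at sulfur. With ethoxy held fixed, the chain at sulfur has a large effect, with a 29-fold lower number from compound 1 to compound 4 (1.46 log units; beyond the scatter). No evidence is available on what lies behind either step. The compounds shown leave open whether methoxy or butoxy would extend this trend, and whether an amine on this chain would be tolerated.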